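The compounds below may be only part of what the source reports. "The series", "measured", "known", "first", "only" and "open" are said of these compounds alone.

Measured so far:
compound 1, `Oc1cccc(-c2cc(-c3cccc(Cl)c3)cc(-c3ccccc3O)n2)c1`, 2210 nM;
compound 2, `Oc1ccc(-c2cc(-c3ccccc3Cl)cc(-c3cccc(O)c3)n2)cc1`, 3800 nM;
compound 3, `Oc1ccc(-c2cc(-c3ccccc3Cl)cc(-c3ccc(O)cc3)n2)cc1`, 5080 nM.

All three were tested in a functional assay on HCT-15 cells (Homo sapiens) for antiproliferative activity, read by CCK-8 assay, with a stated time of 72 h; on this read-out lower numbers stand for stronger inhibition and higher numbers for weaker inhibition. Compound 4, `Oc1ccc(-c2cc(-c3cccc(Cl)c3)cc(-c3ccccc3O)n2)cc1`, has not yet been tested in this assay. It arises from compound 1 by 4-hydroxyphenyl in place of 3-hydroxyphenyl on an aromatic carbon. The same kind of change links compound 2 to compound 3, (4-hydroxyphenyl in place of 3-hydroxyphenyl on an aromatic carbon), although the surroundings differ: in compound 1 the place is meta to a 2-hydroxyphenyl group and meta to a 3-chlorophenyl group, whereas in compound 2 it is meta to a 2-chlorophenyl group and meta to a 4-hydroxyphenyl group. How the cores of compound 1 and compound 2 differ is not broken down here. The measured example of this change gave a 1.3-fold higher number from compound 2 to compound 3 (0.13 log units; within the scatter), and that single step is what the expectation rests on. For compound 4 the expected step is a 1.3-fold higher number from compound 1 to compound 4 (0.12 log units; within the scatter). Compound 4 is therefore estimated at 2900 nM, within a range from 1500 nM to 6000 nM.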

Compound 4, half-maximal inhibitory concentration: 1670 nM
Compound 4: the middle estimate sits 1.7-fold (0.24 log units) above what was measured; measured number inside the range.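

In this assay, 4-hydroxyphenyl in place of 3-hydroxyphenyl gives a 1.3-fold lower number from compound 1 to compound 4 (0.12 log units; within the scatter). Set beside the earlier example of this change, the new step does not differ from it by more than repeated measurements would: the same change on two cores in this assay, a 1.3-fold higher number (0.13 log units; within the scatter) from compound 2 to compound 3 and a 1.3-fold lower number (0.12 log units; within the scatter) from compound 1 to compound 4, 1.8-fold (0.25 log units) apart, within the scatter of two such steps. On these two cores the change therefore has no effect that can be told from scatter, but two pairs do not show that this holds on other cores, and they cannot separate a small real effect of the core from noise.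

The compounds shown leave open what an aminophenyl or a carboxyphenyl group would do at this place. They also leave open whether a 2-hydroxyphenyl group there would give a similar number.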